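Series notes: vinyl replacing nitro, cytotoxicity expectation

The source may hold more compounds than are shown below. What is called first, only, known or untested is meant among the compounds shown, and "the series" means these compounds.

Compound 1 `C/C(=C\c1cc(-c2ccccc2)cs1)C(N)=O` is the unsubstituted parent of the pair measured so far. In an ADME assay on NIH3T3 cells (Mus musculus) for cytotoxicity, read by CCK-8 assay, with a stated time of 24 h (a higher number here means a weaker inhibitor, a lower number a stronger inhibitor), compound 1 gives > 50000 nM, which is a limit of the assay and not a number. Compound 2 `C/C(=C\c1cc(-c2ccc([N+](=O)[O-])cc2)cs1)C(N)=O` carries a nitro group. In this assay compound 2 gives > 50000 nM, again a limit rather than a measured number. The step that the two limits leave unreadable from compound 1 to compound 2 is therefore of unreadable size. Both values sit at the limit of > 50000 nM in this assay, at which 2 of the 2 values shown sit, so compound 2 stands at the limit of the assay, with no measured figure separating it from compound 1.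

Compound 3 `C=Cc1ccc(-c2csc(/C=C(\C)C(N)=O)c2)cc1` differs from compound 2 by vinyl in place of nitro on an aromatic carbon. Among the measured compounds shown here, the only measured step bearing on this position is a step that the two limits leave unreadable from compound 1 to compound 2, and its size cannot be read. For the measured compounds named here, no measured step in this assay shows a change beyond the scatter, so nothing in the data points to a readable shift for compound 3. The expected step of a number no higher from compound 2 to compound 3 (the limit leaves the size open) is none beyond the scatter. Compound 3 is therefore expected to give 50000 nM in this assay, with a range from 20000 nM to 120000 nM, and most likely the assay will again report only a limit.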

Compound 3, half-maximal inhibitory concentration: > 50000 nM
Compound 3 ended at the assay's limit (the forecaster's own chance of this, stated with the estimate: 80%); the middle value lies on the limit itself.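

No new step can be read among compound 1, compound 2 and compound 3 in this assay because all three stand at one limit of the assay, not at a number: the limit of > 50000 nM in this assay, at which 3 of the 3 values shown sit.

The compounds shown leave open how far each of the three lies from that limit, and which change on the shared core, if any, would give a readable value.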